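A few compounds are considered here, and "the series" means these few. Any claim that something is new, unique, unknown or untested is made for them only; others in the source may bear on it.

Measured compounds in a functional assay on DLD-1 cells (Homo sapiens) for inhibition; on this read-out higher numbers stand for weaker inhibition of growth and lower numbers for stronger inhibition of growth:

- compound 1, `CO[C@H]1C[C@H](C)Cc2cc(O)cc(c2)NC(=O)/C=C/CC[C@H](OC)[C@@H](OC(N)=O)/C(C)=C/[C@H](C)[C@H]1O`, a limit of the assay rather than a number: > 10000 nM.
- compound 2, `COc1c2cc(cc1OC(C)=O)NC(=O)/C(C)=C/CC[C@H](OC)[C@@H](OC(N)=O)/C(C)=C/[C@H](C)[C@@H](O)[C@@H](OC)C[C@H](C)C2`: 3520 nM.
- compound 3, `CO[C@H]1C[C@H](C)Cc2cc(cc(O)c2O)NC(=O)/C(C)=C/CC[C@H](OC)[C@@H](OC(N)=O)/C(C)=C/[C@H](C)[C@H]1O`: 9400 nM.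

The result of compound 1 is a limit only (the limit of > 10000 nM in this assay, at which 1 of the 3 values shown sits), so it gives no number to set against the others. Of the two numbers in hand, compound 3 stands highest; compound 2 sits lower, and the gap between them is beyond the scatter.

Next in the series is compound 4, `COc1c(O)cc2cc1C[C@@H](C)C[C@H](OC)[C@H](O)[C@@H](C)/C=C(\C)[C@H](OC(N)=O)[C@@H](OC)CC/C=C(\C)C(=O)N2`, not yet measured. Compared with compound 3 it differs in one place:

methyl in place of hydrogen on an oxygen on an aromatic ring

Among the measured compounds shown here, no measured pair carries this exact change, so there is no step to lean on. Compound 2, which also carries a methoxy on its aromatic ring, shows the lower of the two numbers with 3520 nM, and that is the only pointer available. On that basis a modest move toward stronger inhibition is expected for compound 4, with the step from compound 3 estimated as a 2.7-fold lower number from compound 3 to compound 4 (0.43 log units; beyond the scatter). For compound 4 the value in this assay is expected to be about 3500 nM, estimated to fall between 900 nM and 14000 nM.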

Compound 4, concentration for 50% growth inhibition: 2080 nM
Estimate against measurement, compound 4: 1.7-fold (0.23 log units) above, and the stated range covers the measured number.
By their numbers in this assay, from the lowest: compounds 4 and 2 (each within the scatter of the next); then compound 3. At a limit, above all of these: compound 1.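

In this assay, among the compounds shown here, methyl in place of hydrogen on this oxygen on an aromatic ring gives the first step between compounds that differ in one place: a 4.5-fold lower number from compound 3 to compound 4 (0.66 log units; beyond the scatter). For the compounds shown here, the hydroxy to methoxy change thus has a modest effect of its own on this read-out, which the earlier compounds could only hint at, since compound 2 differs from compound 3 in more than one place. Acetyl and hydrogen on the other oxygen on the aromatic ring cannot be told apart here, with the methoxy in place in both compounds: a 1.7-fold lower number from compound 2 to compound 4 (0.23 log units; within the scatter). Nothing measured in the series bears on why the methyl changes the number.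

As far as these compounds go, it remains open whether an ethyl group or a longer chain on the same oxygen would extend the step or reverse it. From the compounds shown here alone, it is also open how an amine in place of the hydroxy on the aromatic ring would read in this assay, and whether the methoxy step holds on a different core.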